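Removing a Methyl from the Benzyl Amide

This account rests on a few compounds, and the source may have more. Where it says the series, first, only, none or still open, it means among the compounds named here.

Compound 1 `C=CC1=C(C(=O)NCc2ccc(C)cc2)C(c2ccc(F)cc2)OC1`: in a functional assay on A549 cells (Homo sapiens) for cytotoxicity, read by MTT assay, with a stated time of 24 h (a lower number here means a stronger inhibitor, a higher number a weaker inhibitor), compound 1 gives > 100000 nM, which is a limit of the assay.
Compound 2 `C=CC1=C(C(=O)NCC(C)C)C(c2ccc(Cl)c(Cl)c2)OC1`: in this assay compound 2 gives > 100000 nM, also a limit.
Compound 3 `C=CC1=C(C(=O)Nc2ccccc2)C(c2ccc(Cl)c(Cl)c2)OC1`: in this assay compound 3 gives > 100000 nM, again a limit.

Compound 1 therefore stands exactly where the other two measured compounds stand, at the point described by the limit of > 100000 nM in this assay, at which 3 of the 3 values shown sit, with no number of its own. Going by the values given here, the only measured step, a step that the two limits leave unreadable from compound 2 to compound 3, replaces isobutyl with phenyl on an amide-type nitrogen, and its size cannot be read because the limit of > 100000 nM in this assay, at which 3 of the 3 values shown sit, holds both of its ends.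

Compound 4 `C=CC1=C(C(=O)NCc2ccccc2)C(c2ccc(F)cc2)OC1` is compound 1 with the change (hydrogen in place of methyl on an aromatic carbon), that is, 4-methylbenzyl to benzyl. Among the compounds with values here, no measured step touches this change, and every value so far is a limit, so the expectation rests on that alone. Compound 4 is expected to give 150000 nM, within 60000 nM to 400000 nM. The estimated step that the limit leaves unreadable from compound 1 to compound 4 is expected to be none beyond the scatter, most likely ending in another limit.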

Compound 4, half-maximal inhibitory concentration: > 100000 nM
Compound 4: only a limit was reported; the forecaster's own chance of this, stated with the estimate: 80%; the middle value is on the limit's open side.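

No step can be read from compound 1 to compound 4, since each value is only a limit and not a number: the limit of > 100000 nM in this assay, at which 4 of the 4 values shown sit.

What the compounds shown leave open is whether this assay would show any difference between the 4-methylbenzyl and benzyl amides, or any measurable potency for these four compounds.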